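Methoxy on the anilino arm: weak inhibition expected

The compounds below may be only part of what the source reports. "The series", "measured", "known", "first", "only" and "open" are said of these compounds alone.

Measured compounds:
compound 1 `OCCCNCc1nc2c(OCC3CCCCC3)cccc2[nH]1`: 28500 nM
compound 2 `c1ccc(NCc2nc3c(OCC4CCCCC4)cccc3[nH]2)cc1`: > 30000 nM

In an assay on cells for inhibition of interleukin-5 receptor subunit alpha (Mus musculus), read by WST assay, with a stated time of 48 h, in the presence of a further agent that is not named here (a higher number here means a weaker inhibitor, a lower number a stronger inhibitor), compound 1 gives 28500 nM. For compound 2 the assay records only a limit, > 30000 nM. Within the data shown here, the single measured step, an at least 1.0-fold higher number from compound 1 to compound 2 (0.02 log units; that floor lies within the scatter), therefore gives only a floor; compound 2 stands at the limit of > 30000 nM in this assay, at which 1 of the 2 values shown sits, and no number for it is known.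

Compound 3 `COc1ccc(NCc2nc3c(OCC4CCCCC4)cccc3[nH]2)cc1` differs from compound 2 by methoxy in place of hydrogen on an aromatic carbon. Among the measured compounds shown here, no measured step touches this position. For the measured compounds named here, the only step in hand, an at least 1.0-fold higher number from compound 1 to compound 2 (0.02 log units; that floor lies within the scatter), concerns the group on the amine nitrogen and already ends at the limit, so it offers no direction for the present change beyond the scatter.

Compound 3 is therefore expected to sit at or near the limit as well, with an estimated value of 40000 nM, between 15000 nM and 120000 nM. The expected step from compound 2 is a step that the limit leaves unreadable from compound 2 to compound 3, with a substantial chance that this assay again reports only a limit for compound 3.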

Compound 3, half-maximal inhibitory concentration: > 30000 nM
Compound 3: only a limit was reported; the forecaster's own chance of this, stated with the estimate: 70%; the middle value lies beyond the limit too.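

In this assay compound 3 is recorded only as a limit, > 30000 nM. The steps from compound 2 cannot be read, since both ends are limits, so methoxy in place of hydrogen on this aromatic carbon does not bring the anilino arm to a measurable value. Against the 3-hydroxypropyl arm there is only a floor, an at least 1.0-fold higher number from compound 1 to compound 3 (0.02 log units; that floor lies within the scatter), so 4-methoxyphenyl on the amine nitrogen, like phenyl, gives no separation beyond the scatter.

As far as these compounds go, it remains open whether any group at this place, such as a carboxylic acid or a dimethylamino group in place of methoxy, gives a readable number on the anilino arm. Also open, from the compounds shown here alone, is whether a longer chain than 3-hydroxypropyl on the amine nitrogen shifts the value of compound 1.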